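A few compounds are considered here, and "the series" means these few. Any claim that something is new, unique, unknown or untested is made for them only; others in the source may bear on it.

Measured so far in a functional assay on MOLT-3 cells (Homo sapiens) for cytotoxicity, read by MTT assay, with a stated time of 48 h; a lower number here means a stronger inhibitor, a higher number a weaker inhibitor:
Compound 1 `Cc1ccccc1OCc1cn(-c2ccc(S(=O)(=O)N3CCc4ccccc4C3)cc2)nn1`: > 50 ug/mL, a limit of the assay.
Compound 2 `COc1cc2c(cc1OC)CN(S(=O)(=O)c1ccc(-n3cc(COc4ccc(C)cc4)nn3)cc1)CC2`: > 50 ug/mL, likewise a limit of the assay.

In this assay compound 1 therefore stands only at a limit, since (the limit of > 50 ug/mL in this assay, at which 2 of the 2 values shown sit). Compound 3 `O=S(=O)(c1ccc(-n2cc(COc3ccc4ccccc4c3)nn2)cc1)N1CCc2ccccc2C1` differs from it by naphthalen-2-yl in place of 2-methylphenyl on an oxygen on a saturated carbon. Among the measured compounds shown here, no step between measured compounds is available to guide the change, so the account expects nothing beyond the scatter from this replacement, giving a number no higher from compound 1 to compound 3 (the limit leaves the size open) as the expected step. Compound 3 is thus estimated at 50 ug/mL, within a range of 20 ug/mL to 100 ug/mL, and is expected most likely to be reported again only as a limit.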

Compound 3, half-maximal inhibitory concentration: > 50 ug/mL
Compound 3: a limit, no number; the forecaster's own chance of this, stated with the estimate: 75%; the middle value lies on the limit itself.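

Among the compounds shown here, compound 1 and compound 3 both stand only at a limit in this assay, so no step between them can be read: the limit of > 50 ug/mL in this assay, at which 3 of the 3 values shown sit. The compounds shown leave open whether any replacement of 2-methylphenyl would give a readable number in this assay.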